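A few compounds are considered here, and "the series" means these few. Any claim that something is new, unique, unknown or untested is made for them only; others in the source may bear on it.

Three related amides sharing one core have been tested in an ADME assay on NIH3T3 cells (Mus musculus) for cytotoxicity, read by MTT assay, with a stated time of 24 h; on this read-out higher numbers stand for weaker inhibition and lower numbers for stronger inhibition. Compound 1, `COc1ccc(NC(=O)CSc2nnc(CCSc3nncn3C)o2)cc1`, gives > 500 ug/mL in this assay, which is a limit of the assay rather than a number. Compound 2, `Cn1cnnc1SCCc1nnc(SCC(=O)Nc2ccc(F)cc2)o1`, gives > 500 ug/mL in this assay, again a limit. Compound 3, `Cn1cnnc1SCCc1nnc(SCC(=O)Nc2nc3ccc(F)cc3s2)o1`, gives > 500 ug/mL in this assay, also a limit. Within the data shown here, the only pair that differs in a single place gives a step that the two limits leave unreadable from compound 1 to compound 2, so its size cannot be read. Where compound 2 stands is therefore known only as this limit; the two other values shown are limits as well, and the limit of > 500 ug/mL in this assay, at which 3 of the 3 values shown sit, describes where all three sit.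

Compound 4, `Cn1cnnc1SCCc1nnc(SCC(=O)Nc2ccc([N+](=O)[O-])cc2)o1`, has not yet been measured. Its difference from compound 2 is nitro in place of fluoro on an aromatic carbon.

Among the measured compounds shown here, no measured step can show how this change acts in this assay, since the one step between measured compounds is unreadable. What the numbers do show is that every measured compound sits at the limit of > 500 ug/mL in this assay, at which 3 of the 3 values shown sit. The expectation for compound 4 is therefore no step beyond the scatter, a number no higher from compound 2 to compound 4 (the limit leaves the size open), and most likely another limit. Compound 4 is estimated at 500 ug/mL, with a range from 250 ug/mL to 1000 ug/mL.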

Compound 4, half-maximal inhibitory concentration: > 500 ug/mL
Compound 4 was reported as a limit; the forecaster's own chance of this, stated with the estimate: 75%; the middle value sits exactly at the limit.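

In this assay compound 4 gives > 500 ug/mL, which is a limit and not a number. The steps from compound 2 and from compound 1 to compound 4 therefore cannot be read, and compounds 1 to 4 all stop at the same point: the limit of > 500 ug/mL in this assay, at which 4 of the 4 values shown sit. The compounds shown leave open whether methoxy, fluoro and nitro differ in their effect on these cells at all.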